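This account rests on a few compounds, and the source may have more. Where it says the series, first, only, none or still open, it means among the compounds named here.

In an ADME assay on the whole organism (serum) with Homo sapiens as the target (on this read-out lower numbers stand for a shorter-lived compound and higher numbers for a longer-lived compound), compound 2 `Cc1cn(C2CC(N=[N+]=[N-])C(COC(=O)OCCCCCCO)O2)c(=O)[nH]c1=O` gives 0.117 h, the lower of the two exact numbers available. Compound 3 `Cc1cn(C2CC(N=[N+]=[N-])C(COC(=O)CCCC(=O)O)O2)c(=O)[nH]c1=O` gives 30 h. Compound 1 `Cc1cn(C2CC(N=[N+]=[N-])C(COC(=O)NCCCC(=O)OC(C)(C)C)O2)c(=O)[nH]c1=O`, which also ends in tert-butoxycarbonyl, gives > 48 h, and this is a limit of the assay rather than an exact number. Compound 4 `Cc1cn(C2CC(N=[N+]=[N-])C(COC(=O)CCCC(=O)OC(C)(C)C)O2)c(=O)[nH]c1=O` carries 3-(tert-butoxycarbonyl)propyl in place of (6-hydroxyhexyl)oxy on a carbonyl carbon. The closest measured change swaps the same group for 3-carboxypropyl in compound 3, and that step is large, a 260-fold higher number from compound 2 to compound 3 (2.41 log units; beyond the scatter). A similarly large rise is therefore expected here, with an estimated step of a 130-fold higher number from compound 2 to compound 4 (2.11 log units; beyond the scatter). For compound 4 the expected half-life is 15 h, within an estimated range of 2 h to 48 h.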

Compound 4, half-life: 0.55 h
Estimate against measurement, compound 4: 27-fold (1.44 log units) above; measured number outside the range, below it.
By their numbers in this assay, from the lowest: compound 2; then compound 4; then compound 3. At a limit, above all of these: compound 1.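

Putting 3-(tert-butoxycarbonyl)propyl in place of (6-hydroxyhexyl)oxy on this carbonyl carbon gives only a 4.7-fold higher number from compound 2 to compound 4 (0.67 log units; beyond the scatter) in this assay, so a four-carbon chain here does not by itself bring a long half-life. The end of that chain matters too: tert-butyl in place of hydrogen on the oxygen next to a carbonyl group gives a 55-fold lower number from compound 3 to compound 4 (1.74 log units; beyond the scatter), a large change from one place alone.

As far as these compounds go, how an amine at the end of this chain, or a longer chain, would behave remains open. No measurement shown explains why the tert-butyl ester lowers the half-life.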